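Adding two methyl groups to the thiophene of compound 3

The compounds below may be only part of what the source reports. "The series", "measured", "known", "first", "only" and "open" are said of these compounds alone.

Measured so far in a functional assay on cells (Cancer cell lines, Homo sapiens) for inhibition (on this read-out higher numbers stand for weaker inhibition of growth and lower numbers for stronger inhibition of growth), the series reads as follows

Compound 1 `Cc1cn2c(/C=N/NC(=N)N)c(-c3ccsc3)nc2s1` gives 22400 nM
Compound 2 `N=C(N)N/N=C/c1c(-c2cc(Cl)sc2Cl)nc2n1CCS2` gives 22900 nM
Compound 3 `N=C(N)N/N=C/c1c(-c2ccsc2)nc2sccn12` gives 31600 nM

All three values lie within the scatter of one another, so compound 3 stands level with the other two on these numbers. The next compound to be measured is compound 4 `Cc1cc(-c2nc3sccn3c2/C=N/NC(=N)N)c(C)s1`. The change from compound 3 is 2,5-dimethylthiophen-3-yl in place of thiophen-3-yl on an aromatic carbon and amounts to 2,5-dimethylthiophen-3-yl in place of thiophen-3-yl on an aromatic carbon.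

Among the compounds with values here, only one measured step links two compounds that differ in one place. That step, a 1.4-fold higher number from compound 1 to compound 3 (0.15 log units; within the scatter), concerns a methyl on the core and not the group that changes here, so it bears on this change only indirectly. Compound 2 also carries extra groups on its thiophene, but its core differs as well, so it offers no clean comparison. Within the data shown here, nothing measured so far points to a large shift in this assay, and no step beyond the scatter is expected. The expected step is a 1.4-fold lower number from compound 3 to compound 4 (0.14 log units; within the scatter). For compound 4 the estimated value is 23000 nM, with an expected range of 11000 nM to 45000 nM.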

Compound 4, concentration for total growth inhibition: 30200 nM
For compound 4 the middle estimate is 1.3-fold (0.12 log units) below the measured one; low and high end bracket the measured number.
By their numbers in this assay, from the lowest: compounds 1, 2, 4 and 3 (each within the scatter of the next).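

In this assay the replacement of thiophen-3-yl by 2,5-dimethylthiophen-3-yl (a 1.0-fold lower number from compound 3 to compound 4 (0.02 log units; within the scatter)) is the only step shown at this position, and it stays within the scatter. On the shared core, the group at this aromatic carbon can therefore grow from 5 to 7 heavy atoms, through two methyl groups on the thiophene, with the read-out staying level. No available evidence bears on this result.

The compounds shown leave open whether a group of another kind at this place, such as a phenyl ring, a carboxylic acid or a chain carrying an amine, would move the number beyond the scatter. They also leave open what a single methyl on the thiophene would do, and with the four compounds each within the scatter of the next in this assay no ordering of the groups can be drawn from them.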